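The compounds below may be only part of what the source reports. "The series", "measured", "known", "first", "only" and "open" are said of these compounds alone.

Compound 1 `Cc1cccc(Cn2cc(COc3ccc4c(=O)ccoc4c3)nn2)c1` in a functional assay on SGC-7901 cells (Homo sapiens) for cytotoxicity, read by MTT assay, with a stated time of 48 h (on this read-out higher numbers stand for weaker inhibition and lower numbers for stronger inhibition), gives only the assay limit > 100000 nM.
Compound 2 `O=c1ccoc2cc(OCc3cn(Cc4cccc(F)c4)nn3)ccc12` in this assay gives only the assay limit > 100000 nM.
Compound 3 `O=c1ccoc2cc(OCc3cn(Cc4ccccc4)nn3)ccc12` in this assay gives only the assay limit > 100000 nM.

Compound 3 therefore stands at the limit of this assay, and so do the other two measured compounds, as the limit of > 100000 nM in this assay, at which 3 of the 3 values shown sit, records. Compound 4 `O=c1ccoc2cc(OCc3cn(Cc4cccc(Cl)c4)nn3)ccc12` differs from compound 3 by chloro in place of hydrogen on an aromatic carbon. Going by the values given here, the steps that bear on this change are those on the same ring carbon: a step that the two limits leave unreadable from compound 2 to compound 3, a step that the two limits leave unreadable from compound 1 to compound 3 and a step that the two limits leave unreadable from compound 1 to compound 2. None of them can be read, since every value involved is a limit, so no size or direction of step is known for any substituent on that carbon. With all three measured compounds at the limit and no readable step, the step expected in this assay is a number no higher from compound 3 to compound 4 (the limit leaves the size open), meaning that compound 4 is expected to remain at the limit rather than to show a measurable shift. Compound 4 is estimated to give 100000 nM in this assay, within a range from 30000 nM to 300000 nM.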

Compound 4, half-maximal inhibitory concentration: > 100000 nM
Compound 4: a limit, no number; the forecaster's own chance of this, stated with the estimate: 80%; the middle value lies on the limit itself.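

Going by these compounds alone, compound 4 also gives only a limit, so no step among compound 1, compound 2, compound 3 and compound 4 can be read, as all four values are limits: the limit of > 100000 nM in this assay, at which 4 of the 4 values shown sit. The compounds shown leave open how strongly any of them inhibits, and whether hydrogen, methyl, fluoro or chloro on that aromatic carbon makes any difference.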